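The source may hold more compounds than are shown below. What is called first, only, known or untested is meant among the compounds shown, and "the series" means these compounds.

Compounds measured in a functional assay on Lu1 cells (Homo sapiens) for cytotoxicity; a higher number here means that more compound is needed for the effect, a lower number that less compound is needed:
compound 1, `CCC[C@@H](OC(C)=O)C1=C(Br)[C@@](C)(OC)OC1=O`, > 20 ug/mL
compound 2, `CCC[C@@H](OC(C)=O)C1=C(Br)[C@@](OC)(C(Br)Br)OC1=O`, > 20 ug/mL
compound 3, `CCC[C@@H](OC(C)=O)C1=C(Br)[C@](OC)(C(Br)Br)OC1=O`, > 20 ug/mL

Every one of these values is a limit of this assay rather than a number. Compound 1 gives only the limit > 20 ug/mL. Compound 2 likewise gives only a limit, > 20 ug/mL. Compound 3 also gives only a limit, > 20 ug/mL. Compound 2 therefore stands at the limit of this assay, with no number that would place it against the others.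

Compound 4, `CCC[C@@H](OC(C)=O)C1=C(Br)[C@](C)(OC)OC1=O`, has not yet been measured. It differs from compound 2 by methyl in place of dibromomethyl on a saturated ring carbon. Among the compounds with values here, two measured steps bear on this change. The step that the two limits leave unreadable from compound 1 to compound 3 makes the same exchange in the opposite direction, and the step that the two limits leave unreadable from compound 2 to compound 3 rests on (the fact that compounds 2 and 3 differ only in the configuration as drawn); both stay unreadable because of the limit of > 20 ug/mL in this assay, at which 3 of the 3 values shown sit. Within the data shown here, no size and no direction can be read from them, so the only expectation is that compound 4, like the others, sits at the limit. Compound 4 is expected to give 30 ug/mL, between 15 ug/mL and 80 ug/mL. The expected step that the limit leaves unreadable from compound 2 to compound 4 is therefore none beyond the scatter.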

Compound 4, concentration for half-maximal effect: > 20 ug/mL
Compound 4 was reported as a limit; the forecaster's own chance of this, stated with the estimate: 85%; the middle value does not contradict the limit.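

Compound 4 adds no readable step against compound 2 or compound 1, and neither its size nor its direction can be read, for one reason: the limit of > 20 ug/mL in this assay, at which 4 of the 4 values shown sit.

Going by these compounds, whether methyl in place of dibromomethyl, or the configuration as drawn at the saturated ring carbon, changes the result in this assay stays open.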